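The source may report more compounds than this note shows. Statements on the series, on what has been measured and on what is new or still open speak of the compounds shown alone.

Measured compounds in a functional assay on FM3A cells (Mus musculus) for cytotoxicity, read by cell counting, with a stated time of 2 days; a higher number here means a weaker inhibitor, a lower number a stronger inhibitor: compound 1 `CC(C)(C)c1ccc(CN2C(=O)S/C(=C\c3ccc(N)cc3)C2=O)cc1` gives 80000 nM; compound 2 `Nc1ccc(/C=C2\SC(=O)N(Cc3ccc(Cl)cc3)C2=O)cc1` gives 60000 nM; compound 3 `Nc1ccc(/C=C2\SC(=O)N(Cc3cccc(Cl)c3)C2=O)cc1` gives 10000 nM.

Compound 3 has the lowest number of the three, with a 6.0-fold lower number from compound 2 to compound 3 (0.78 log units; beyond the scatter) and an even larger gap to compound 1. Compound 4 `Cc1ccc(CN2C(=O)S/C(=C\c3ccc(N)cc3)C2=O)cc1` differs from compound 3 by 4-methylphenyl in place of 3-chlorophenyl on a saturated chain carbon bound to an amide-type nitrogen in a ring. Going by the values given here, two steps bear on this change. The shift a 6.0-fold lower number from compound 2 to compound 3 (0.78 log units; beyond the scatter) shows that 3-chlorophenyl gave a lower number than 4-chlorophenyl; compound 4 returns to 4-substitution. The swap of substituent on that ring, a 1.3-fold lower number from compound 1 to compound 2 (0.12 log units; within the scatter), stayed within the scatter. A higher number for compound 4 than for compound 3 is therefore expected, roughly reversing that step, a 4.0-fold higher number from compound 3 to compound 4 (0.60 log units; beyond the scatter). The estimate for compound 4 in this assay is 40000 nM, within 15000 nM to 100000 nM.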

Compound 4, half-maximal inhibitory concentration: > 250000 nM
Compound 4: only a limit was reported; the forecaster's own chance of this, stated with the estimate: 5%; middle value at least 6.2-fold (0.79 log units) away from the limit.
By their numbers in this assay, from the lowest: compound 3; then compounds 2 and 1 (each within the scatter of the next). At a limit, above all of these: compound 4.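

In this assay compound 4 is reported only as a limit, > 250000 nM. On this saturated chain carbon, methyl separates clearly from the other two substituents on that ring, with an at least 4.1-fold higher number from compound 2 to compound 4 (0.61 log units; beyond the scatter) and an at least 3.1-fold higher number from compound 1 to compound 4 (0.49 log units; beyond the scatter), even though chloro and tert-butyl stayed within the scatter of each other. The change from 3-chlorophenyl gives the largest step of the series, an at least 25-fold higher number from compound 3 to compound 4 (1.39 log units; beyond the scatter). From the compounds shown here alone, whether 3-methylphenyl would read like compound 3 or like compound 4 remains open, so the roles of substituent and ring position are not separated. Going by these compounds, how an amine or a carboxylic acid on that ring would read is also open.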